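Thiophene in place of bromophenyl on the carbonyl

The source may report more compounds than this note shows. Statements on the series, on what has been measured and on what is new or still open speak of the compounds shown alone.

Two compounds share one core here. Compound 1 `COc1cc(-c2nnc3n2NC(c2ccco2)C(C(=O)c2ccccc2C)S3)cc(OC)c1OC` carries a 2-methylphenyl on the carbonyl carbon, and in a functional assay on A549 cells (Homo sapiens) for cytotoxicity, read by MTT assay, with a stated time of 48 h (a higher number here means a weaker inhibitor, a lower number a stronger inhibitor), compound 1 gives 80000 nM. Compound 2 `COc1cc(-c2nnc3n2NC(c2ccco2)C(C(=O)c2ccc(Br)cc2)S3)cc(OC)c1OC` carries a 4-bromophenyl there instead, and in this assay compound 2 gives 42100 nM. Within the data shown here, the only step on record, a 1.9-fold lower number from compound 1 to compound 2 (0.28 log units; within the scatter), lies within the scatter, so compound 2 and compound 1 cannot be told apart on these numbers.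

Compound 3 `COc1cc(-c2nnc3n2NC(c2ccco2)C(C(=O)c2cccs2)S3)cc(OC)c1OC` differs from compound 2 by one change: thiophen-2-yl in place of 4-bromophenyl on a carbonyl carbon. Among the measured compounds shown here, the step from compound 1 to compound 2 is the only one bearing on an exchange at this carbonyl, and it was small. No thiophene has been measured on this core. Compound 3 is therefore expected to stay close to compound 2, with a step of a 1.3-fold higher number from compound 2 to compound 3 (0.12 log units; within the scatter) that need not rise above the scatter. Compound 3 is estimated at 55000 nM, within a range from 20000 nM to 150000 nM.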

Compound 3, half-maximal inhibitory concentration: 78700 nM
Compound 3: middle estimate off by 1.4-fold (0.16 log units), on the low side; measured number inside the range.
By their numbers in this assay, from the lowest: compounds 2, 3 and 1 (each within the scatter of the next).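

Among these compounds, compound 3 brings a five-membered aromatic ring with one hetero atom to the carbonyl carbon, where the earlier compounds held only six-membered aromatic rings of carbon. In this assay, the new steps, a 1.9-fold higher number from compound 2 to compound 3 (0.27 log units; within the scatter) and a 1.0-fold lower number from compound 1 to compound 3 (0.01 log units; within the scatter), both stay within the scatter, so 2-methylphenyl, 4-bromophenyl and thiophen-2-yl cannot be told apart at this position, and this change of ring size and ring atoms does not separate the three compounds. Nothing on record explains why these numbers stay together.

On these data alone, all three groups are aromatic rings, so it remains open whether an amine, a carboxylic acid or a longer alkyl chain on this carbonyl carbon would give a step beyond the scatter. As far as these compounds go, it also remains open whether changes elsewhere on the shared core would do so.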